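This account rests on a few compounds, and the source may have more. Where it says the series, first, only, none or still open, it means among the compounds named here.

Compound 1 `Cc1cn([C@@H]2O[C@H](CO[Si](C)(C)C(C)(C)C)[C@@]3(OS(=O)(=O)C=C3N)[C@H]2O[Si](C)(C)C(C)(C)C)c(=O)n(C(=O)OC(C)(C)C)c1=O`: 26000 nM
Compound 2 `Cc1cn([C@@H]2O[C@H](CO[Si](C)(C)C(C)(C)C)[C@@]3(OS(=O)(=O)C=C3N)[C@H]2O[Si](C)(C)C(C)(C)C)c(=O)n(C(=O)CCCBr)c1=O`: 11000 nM

In an ADME assay on CCRF-CEM cells (Homo sapiens) for cytotoxicity, with a stated time of 4 days (a higher number here means that more compound is tolerated, a lower number that less compound is tolerated), compound 2 has the lower of the two numbers, at 11000 nM, while compound 1 gives 26000 nM. Compound 3 `CSC(=O)CCCC(=O)n1c(=O)c(C)cn([C@@H]2O[C@H](CO[Si](C)(C)C(C)(C)C)[C@@]3(OS(=O)(=O)C=C3N)[C@H]2O[Si](C)(C)C(C)(C)C)c1=O` keeps the shared core of compound 2 and alters the end of its chain: (methylsulfanyl)carbonyl in place of bromo on a saturated chain carbon, three bonds along the chain from a carbonyl carbon. In other words, 3-bromopropyl becomes 3-((methylsulfanyl)carbonyl)propyl.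

Going by the values given here, only one measured step bears on this change: a 2.4-fold lower number from compound 1 to compound 2 (0.37 log units; beyond the scatter). It is modest and also alters the group on a carbonyl carbon, replacing tert-butoxy with 3-bromopropyl. Among the compounds with values here, no measured pair shows the bromo being replaced on the chain, so this evidence is indirect. Within the data shown here, compound 3 loses the bromo, and compound 1, the only measured compound without it, gives 26000 nM. A small upward move in this assay is therefore expected, no larger than that modest step and quite possibly lost in the scatter. The estimated change is a 1.4-fold higher number from compound 2 to compound 3 (0.13 log units; within the scatter). For compound 3 the estimated value is 15000 nM, with an expected range from 7000 nM to 32000 nM.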

Compound 3, half-maximal cytotoxic concentration: 9900 nM
Estimate against measurement, compound 3: 1.5-fold (0.18 log units) above; the range from low to high includes it.
By their numbers in this assay, from the lowest: compounds 3 and 2 (each within the scatter of the next); then compound 1.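

In this assay, replacing bromo with (methylsulfanyl)carbonyl on a saturated chain carbon, three bonds along the chain from a carbonyl carbon, gives a 1.1-fold lower number from compound 2 to compound 3 (0.05 log units; within the scatter) and so leaves the reading within the scatter, even though 4 heavy atoms enter where 1 leaves. The bromo is therefore not required for the gap from compound 1, since that gap is also present without it (a 2.6-fold lower number from compound 1 to compound 3 (0.42 log units; beyond the scatter)) and is of the same modest kind as the earlier step (a 2.4-fold lower number from compound 1 to compound 2 (0.37 log units; beyond the scatter)). No measurement at hand explains why these two chain ends read alike.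

From the compounds shown here alone, it remains open whether a carboxylic acid or an amine at the end of this chain would also read like bromo and (methylsulfanyl)carbonyl, and whether a longer chain would keep the reading of the 3-substituted propyl chains. All three compounds also share one core, so whether replacing tert-butoxy with such a chain would give a similar step on a different core cannot be judged from them.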